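Methyl for tert-butyl on a dioxane core with a free amine

The source may report more compounds than this note shows. Statements on the series, on what has been measured and on what is new or still open speak of the compounds shown alone.

Compound 2, with the structure `CC(C)(C)[C@@]1(c2ccccc2)OCC[C@@H](CCN)O1`, carries a primary amine at the end of its 2-aminoethyl group and a tert-butyl group on the shared core. In an assay on brain for displacement of a labelled ligand from Sigma non-opioid intracellular receptor 1 (Cavia porcellus) (a lower number here means a stronger inhibitor, a higher number a weaker inhibitor), compound 2 gives > 10000 nM, which is a limit of the assay and not a number. Compound 2 is therefore not placed on the scale at all; it sits at the limit of > 10000 nM in this assay, at which 2 of the 3 values shown sit. Compound 1, with the structure `CC(C)(C)[C@]1(c2ccccc2)OCC[C@H](CCNCc2ccccc2)O1`, carries a benzyl group on the nitrogen and in this assay compound 1 gives 253 nM. Compound 3, with the structure `C[C@]1(c2ccccc2)OCC[C@H](CCN)O1`, carries methyl and the same 2-aminoethyl group, and in this assay compound 3 gives > 10000 nM, again a limit. The next compound, compound 4, has the structure `C[C@@]1(c2ccccc2)OCC[C@@H](CCN)O1` and differs from compound 2 by methyl in place of tert-butyl on a saturated ring carbon. No measured step tells how this change acts in this assay, and the two compounds with a primary amine shown so far both stop at the limit. For compound 4 a step that the limit leaves unreadable from compound 2 to compound 4 is expected, that is, no change beyond the scatter and most likely another limit. Compound 4 is expected to give about 15000 nM, within 5000 nM to 50000 nM.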

Compound 4, inhibition constant: > 10000 nM
Compound 4: a limit, no number; the forecaster's own chance of this, stated with the estimate: 80%; the middle value does not contradict the limit.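

Compound 2, compound 3 and compound 4 all stop at a limit in this assay, and no step can be read from compound 2 to compound 4 or from compound 3 to compound 4. The compounds shown leave open whether tert-butyl versus methyl, or one mirror image versus the other, makes any difference among these primary amines.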